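Swapping Trifluoromethyl for Chloro on a Second Core

This account rests on a few compounds, and the source may have more. Where it says the series, first, only, none or still open, it means among the compounds named here.

Compound 1, `COC(=O)NCC1Cc2ccc(NC(=O)c3cccc(C)c3-c3ccc(C(F)(F)F)cc3)cc2C1`, gives 24 nM in an assay on isolated protein for inhibition of microsomal triglyceride transfer protein large subunit (Homo sapiens); a lower number here means a stronger inhibitor, a higher number a weaker inhibitor.
Compound 2, `COC(=O)NCC1Cc2ccc(NC(=O)c3cccc(C)c3-c3ccc(Cl)cc3)cc2C1`, gives 100 nM in this assay.
Compound 3, `COC(=O)NC1CCc2ccc(NC(=O)c3cccc(C)c3-c3ccc(C(F)(F)F)cc3)cc2CC1`, gives 20 nM in this assay.

Of the compounds shown here, three have been measured so far, and they fall into two groups by their core. Compound 1 and compound 2 share one core and differ only at one spot on the outer aromatic ring: chloro in place of trifluoromethyl on an aromatic carbon. That change brought a 4.2-fold higher number from compound 1 to compound 2 (0.62 log units; beyond the scatter), so the chloro compound is the weaker inhibitor of the pair.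

Compound 3 carries a different core but the same trifluoromethyl-bearing ring as compound 1. The difference between the two cores is not broken down here. In this assay compound 3 and compound 1 give numbers that lie within the usual scatter of each other, so on this evidence the two cores behave alike when the trifluoromethyl group is present.

Compound 4, `COC(=O)NC1CCc2ccc(NC(=O)c3cccc(C)c3-c3ccc(Cl)cc3)cc2CC1`, has not yet been measured. It stands to compound 3 exactly as compound 2 stands to compound 1: chloro in place of trifluoromethyl on an aromatic carbon. This is the same change, at the same kind of place, as the one already seen.

Compound 4 is therefore expected to be a weaker inhibitor than compound 3, with a step of about a 4.3-fold higher number from compound 3 to compound 4 (0.63 log units; beyond the scatter), because a 4.2-fold higher number from compound 1 to compound 2 (0.62 log units; beyond the scatter) and the two cores gave matching numbers with the trifluoromethyl group in place. The expected value for compound 4 in this assay is 85 nM, most likely between 40 nM and 180 nM.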

Compound 4, half-maximal inhibitory concentration: 80 nM
Beside the measured number, compound 4's estimate is 1.1-fold (0.03 log units) above it, within the range that was stated.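

On the second core, chloro in place of trifluoromethyl gives a 4.0-fold higher number from compound 3 to compound 4 (0.60 log units; beyond the scatter) in this assay, so the chloro compound is again the weaker inhibitor of its pair. Going by these compounds alone, the change therefore carries across these two cores with its direction and its size intact: the same change on two cores in this assay, a 4.2-fold higher number (0.62 log units; beyond the scatter) from compound 1 to compound 2 and a 4.0-fold higher number (0.60 log units; beyond the scatter) from compound 3 to compound 4, 1.0-fold (0.02 log units) apart, within the scatter of two such steps This shows that, for these two pairs, the step could be read from one core to the other, but it rests on only two cores, one change and one assay, so it does not show that the step would hold on a third core, and it does not explain why chloro gives the weaker inhibitor.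

From the compounds shown here alone, all four compounds carry either trifluoromethyl or chloro on the outer aromatic ring, so it remains open how a nitrile, a methoxy group or a plain hydrogen at that spot would compare on either core. They also share the same carbamate, which leaves open whether the two cores would still match, and whether the step would keep its size, with an amine or a carboxylic acid in its place.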